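Working notes: compound 3 to compound 4 in cytotoxicity

The source may hold more compounds than are shown below. What is called first, only, known or untested is meant among the compounds shown, and "the series" means these compounds.

Of the compounds shown here, three of the shared core have been measured. Compound 1 `CCN(CC)c1ccc(NC(=O)c2cc(Cl)ccc2O)c(Cl)c1` bears a diethylamino group on an aromatic carbon; in an ADME assay on A549 cells (Homo sapiens) for cytotoxicity, read by resazurin assay, with a stated time of 48 h (on this read-out lower numbers stand for higher toxicity in this test and higher numbers for lower toxicity in this test), compound 1 gives 55500 nM. Compound 2 `CCCN(CCC)c1ccc(NC(=O)c2cc(Cl)ccc2O)c(Cl)c1` carries dipropylamino in place of diethylamino; in this assay compound 2 gives 10700 nM. For the measured compounds named here, the only one-place step between measured compounds is a 5.2-fold lower number from compound 1 to compound 2 (0.71 log units; beyond the scatter). Compound 3 `O=C(Nc1ccc(NCc2ccc(C(F)(F)F)cc2)cc1Cl)c1cc(Cl)ccc1O` instead carries a 4-(trifluoromethyl)phenyl on a saturated chain carbon bound to a nitrogen on an aromatic ring; in this assay compound 3 gives 62700 nM, the highest of the three numbers, within the scatter of compound 1 and beyond the scatter relative to compound 2.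

Compound 4 `O=C(Nc1ccc(NCc2ccc(O)nc2)cc1Cl)c1cc(Cl)ccc1O` is not yet measured. It differs from compound 3 in one place: 6-hydroxypyridin-3-yl in place of 4-(trifluoromethyl)phenyl on a saturated chain carbon bound to a nitrogen on an aromatic ring. Going by the values given here, the single measured step, a 5.2-fold lower number from compound 1 to compound 2 (0.71 log units; beyond the scatter), concerns the dialkylamino group, a different place and a different kind of change, so it does not bear directly on this swap; no measured pair alters the group on the saturated chain carbon. Among the compounds with values here, with no comparable step available, the default expectation in this assay is a move not beyond the scatter, in either direction. Compound 4 is therefore estimated at 70000 nM, with a range of 25000 nM to 200000 nM. This estimate means an expected step of a 1.1-fold higher number from compound 3 to compound 4 (0.05 log units; within the scatter).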

Compound 4, half-maximal cytotoxic concentration: 98500 nM
Beside the measured number, compound 4's estimate is 1.4-fold (0.15 log units) below it, and the stated range covers the measured number.
By their numbers in this assay, from the lowest: compound 2; then compounds 1, 3 and 4 (each within the scatter of the next).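

In this assay, for the compounds shown here, the first measured change to the group on the saturated chain carbon, 6-hydroxypyridin-3-yl in place of 4-(trifluoromethyl)phenyl, gives a 1.6-fold higher number from compound 3 to compound 4 (0.20 log units; within the scatter) and so stays inside the usual scatter. At this place, therefore, a ring of carbon only with no hydrogen-bond donors can give way to a ring with one hetero atom and a hydrogen-bond donor without a read-out move beyond the scatter. Set against the simple dialkylamino compounds, the ((6-hydroxypyridin-3-yl)methyl)amino group gives a 1.8-fold higher number from compound 1 to compound 4 (0.25 log units; within the scatter) and also a 9.2-fold higher number from compound 2 to compound 4 (0.96 log units; beyond the scatter) in the same assay, which leaves compound 2 as the only one of the four set apart beyond the scatter, and no data shown here explain any of these steps.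

As far as these compounds go, whether this tolerance extends to other groups on the saturated chain carbon remains open, since an unsubstituted phenyl or a phenyl bearing a carboxylic acid would test it further. A longer chain such as dibutylamino would show whether the lower number seen with dipropylamino continues along the dialkylamino compounds.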